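This account rests on a few compounds, and the source may have more. Where it says the series, first, only, none or still open, it means among the compounds named here.

- Compound 1 `COc1ccc2cc([C@H](C)c3nnc(SCc4ccc(Cl)cc4)n3-c3ccc(F)cc3)ccc2c1`: > 400000 nM (a limit of the assay)
- Compound 2 `COc1ccc2cc([C@H](C)c3nnc(SCc4ccc(F)cc4)n3-c3ccc(F)cc3)ccc2c1`: 104000 nM

Going by the values given here, in a functional assay on LNCaP cells (Homo sapiens) for cytotoxicity, read by MTT assay (on this read-out higher numbers stand for weaker inhibition and lower numbers for stronger inhibition), compound 2 gives 104000 nM, the only exact number available so far. Compound 1 is reported only as a limit, > 400000 nM.

Compound 3 `COc1ccc2cc([C@H](C)c3nnc(SCc4c(Cl)cccc4Cl)n3-c3ccc(F)cc3)ccc2c1` keeps the rest of compound 2 and replaces the 4-fluorobenzyl group with 2,6-dichlorobenzyl: 2,6-dichlorophenyl in place of 4-fluorophenyl on a saturated chain carbon bound to a sulfur.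

Among the compounds with values here, one measured step bears on this change: an at least 3.8-fold lower number from compound 1 to compound 2 (0.58 log units; beyond the scatter). It is fluoro in place of chloro on an aromatic carbon, so read in reverse it pairs chloro with the higher number. On these data alone, this is thin support, as it rests on a single pair and its true size stays open, given (the limit of > 400000 nM in this assay, at which 1 of the 2 values shown sits). Within the data shown here, no measured compound carries the 2,6-dichlorophenyl group. A modest move toward weaker inhibition is therefore expected, and compound 3 may also end up reported only as a limit. The expected change is a 1.9-fold higher number from compound 2 to compound 3 (0.28 log units; within the scatter). For compound 3 the estimated value is 200000 nM, with an expected range of 60000 nM to 600000 nM.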

Compound 3, half-maximal inhibitory concentration: 12300 nM
The estimate for compound 3 lay 16-fold (1.21 log units) above the measured number, and the stated range ends above it.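

In this assay, going by these compounds alone, the group on a saturated chain carbon bound to a sulfur proves able to move the read-out much further than the one earlier step suggested: 2,6-dichlorophenyl in place of 4-fluorophenyl gives an 8.5-fold lower number from compound 2 to compound 3 (0.93 log units; beyond the scatter), a shift toward stronger inhibition. The same group in place of 4-chlorophenyl gives an at least 32-fold lower number from compound 1 to compound 3 (1.51 log units; beyond the scatter), so chlorine as such does not go with the higher number, since compound 1 and compound 3 both carry it and stand at opposite ends of the three compounds shown. Compound 1 is reported only as a limit, and the true size of that second step stays open: the limit of > 400000 nM in this assay, at which 1 of the 3 values shown sits.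

The two chlorines of compound 3 arrive together, so the compounds shown cannot separate the effect of their number from that of their placement, and the change from 4-fluorophenyl alters both at once. On these data alone, how a phenyl bearing bromo or methyl groups, or an amine at the same place, would read in this assay also remains open.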